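Three measured thiazolidinediones and a chlorophenyl variant

The source may hold more compounds than are shown below. What is called first, only, known or untested is meant among the compounds shown, and "the series" means these compounds.

In a functional assay on the whole organism (plasma) with Mus musculus as the target, with a stated time of 15 days, at a dose of 10 mg/kg by the oral route (on this read-out higher numbers stand for a stronger effect at the one dose given and lower numbers for a weaker effect), the three measured compounds gave:

Compound 1 `Cc1ccc(/C=C2\SC(=O)N(Cc3ccc(C)cc3)C2=O)cc1`: 16.3%
Compound 2 `Cc1ccc(CN2C(=O)S/C(=C\c3ccc(N(C)C)cc3)C2=O)cc1`: 14.9%
Compound 3 `COc1ccc(/C=C2\SC(=O)N(Cc3ccc(C)cc3)C2=O)cc1`: 20.6%

Compound 3 holds the highest of the three numbers, yet its separation from compound 1 is a number 4.3 percentage points higher from compound 1 to compound 3 (within the scatter) and its separation from compound 2 is a number 5.7 percentage points higher from compound 2 to compound 3 (within the scatter), so none of these compounds can be called more active than another. Likewise a number 1.4 percentage points lower from compound 1 to compound 2 (within the scatter) sits inside the scatter. The three measured steps all exchange one group on an aromatic carbon of the same ring and none of them moved the read-out beyond the scatter.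

Compound 4 `Cc1ccc(CN2C(=O)S/C(=C\c3ccccc3Cl)C2=O)cc1` departs from compound 3 elsewhere: 2-chlorophenyl in place of 4-methoxyphenyl on a double-bonded chain carbon bound to a double-bonded ring carbon. Among the measured compounds shown here, no measured step touches this part of the molecule, so the three steps bear on it only indirectly, by showing that changes on an aromatic ring of this series have so far stayed within the scatter. On that basis compound 4 is expected to show a step of a number 3.6 percentage points lower from compound 3 to compound 4 (within the scatter), that is, no change beyond the scatter. The estimate for compound 4 in this assay is 17%, within a range from 7% to 28%.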

Compound 4, a percentage reported as activity, at one dose (the size of the read-out at that dose, not a potency): 19.2%
Beside the measured number, compound 4's estimate is 2.2 percentage points below it; the range from low to high includes it.
By their numbers in this assay, from the lowest: compounds 2, 1, 4 and 3 (each within the scatter of the next).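

In this assay, the place on a double-bonded chain carbon bound to a double-bonded ring carbon is now tested by replacing the whole group rather than exchanging one group on an aromatic carbon, and the result is a number 1.4 percentage points lower from compound 3 to compound 4 (within the scatter) and also a number 2.9 percentage points higher from compound 1 to compound 4 (within the scatter) for the same kind of exchange from 4-methylphenyl. Neither 4-methoxyphenyl nor 4-methylphenyl can therefore be told apart from 2-chlorophenyl on this read-out at the one dose given, even though the exchange swaps the oxygen or the methyl carbon for chlorine and changes the number in the group's name from 4 to 2. The study's data shown here offer no measurement that speaks to the reason for this result.

From the compounds shown here alone, whether a carboxylic acid or an amine on this aromatic ring, or a cyclohexyl group in place of the ring, would move the number beyond the scatter remains open. Also open, going by these compounds, is what happens when the 4-methylbenzyl group, common to all four compounds, is exchanged for a longer chain.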